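The compounds below may be only part of what the source reports. "The series", "measured", "known", "first", "only" and "open" are said of these compounds alone.

Of the compounds shown here, two built on the same core have been measured in an in vitro ADME assay on microsomes from liver (Homo sapiens) for metabolic stability; a higher number here means that the compound lasts longer, a lower number that the compound disappears faster. Compound 1 (`CS(=O)(=O)Nc1ccc2c(c1)S(=O)(=O)N=C(C1=C(O)C3CCCCC3N(Cc3ccc(F)cc3)C1=O)N2`) is drawn without a configuration at its two stereocentres on saturated ring carbons. In this assay compound 1 gives > 1 h, which is a limit of the assay and not a number. Compound 2 (`CS(=O)(=O)Nc1ccc2c(c1)S(=O)(=O)N=C(C1=C(O)[C@H]3CCCC[C@H]3N(Cc3ccc(F)cc3)C1=O)N2`) has the same atoms and bonds, with one of those stereocentres drawn S and the other R. In this assay compound 2 gives > 1 h, again a limit rather than a number. The step that the two limits leave unreadable from compound 1 to compound 2 cannot be read because of the limit of > 1 h in this assay, at which 2 of the 2 values shown sit. Compound 3 (`CS(=O)(=O)Nc1ccc2c(c1)S(=O)(=O)N=C(C1=C(O)[C@@H]3CCCC[C@@H]3N(Cc3ccc(F)cc3)C1=O)N2`) is the mirror image of compound 2: the two compounds have the same atoms and bonds and differ only in configuration as drawn: 2 of 2 stereo elements differ (all stereocentres are inverted: mirror images); a stereocentre at a saturated ring carbon is drawn S in compound 2 and R in compound 3; a stereocentre at a saturated ring carbon is drawn R in compound 2 and S in compound 3. Among the measured compounds shown here, the only measured step, from compound 1 to compound 2, has no readable size, so no change beyond the scatter is expected in this assay. Compound 3 is therefore expected to give 1.5 h, with a range from 0.7 h to 4 h. This means an expected step that the limit leaves unreadable from compound 2 to compound 3.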

Compound 3, half-life: > 1 h
Compound 3: no number, only a limit; the forecaster's own chance of this, stated with the estimate: 70%; the middle value is on the limit's open side.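

The result for compound 3 gives no readable step to compound 1 or compound 2, because all three results are limits of the assay and not numbers: the limit of > 1 h in this assay, at which 3 of the 3 values shown sit.

As far as these compounds go, how long each compound actually lasts in this assay stays open, and so does whether the mirror images compound 2 and compound 3 differ at all.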